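Para-chloro on the benzyl group of compound 2

The source may report more compounds than this note shows. Statements on the series, on what has been measured and on what is new or still open speak of the compounds shown alone.

Measured in an assay on HEK293 cells for displacement of a labelled ligand from 5-hydroxytryptamine receptor 6 (Homo sapiens); on this read-out lower numbers stand for stronger inhibition and higher numbers for weaker inhibition:
compound 1, `O=[N+]([O-])c1ccc(N2CCNCC2)cc1NCCOc1ccccc1`, gives 114 nM
compound 2, `O=[N+]([O-])c1ccc(N2CCNCC2)cc1NCc1ccccc1`, gives 28 nM
compound 3, `NCCNc1ccc([N+](=O)[O-])c(NCc2ccccc2)c1`, gives 1490 nM

Compound 2 has the lowest number of the three: compound 1 is the nearest, with a 4.1-fold lower number from compound 1 to compound 2 (0.61 log units; beyond the scatter), while compound 3 is furthest, with a 53-fold higher number from compound 2 to compound 3 (1.73 log units; beyond the scatter). Both steps lie beyond the scatter, so compound 2 stands as the most potent of the measured set in this assay.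

Compound 4, `O=[N+]([O-])c1ccc(N2CCNCC2)cc1NCc1ccc(Cl)cc1`, differs from compound 2 by chloro in place of hydrogen on an aromatic carbon. Neither measured step bears directly on this change: the step from compound 1 to compound 2 concerns the group on the saturated chain carbon, and the step from compound 2 to compound 3 concerns the group on the aromatic carbon of the core. Nothing among the three compounds probes a substituent on the benzyl ring itself. The change is one heavy atom at a single aromatic position, far smaller than either measured change, and its direction cannot be read from the data.

For compound 4 the expectation in this assay is therefore a step of a 1.1-fold lower number from compound 2 to compound 4 (0.05 log units; within the scatter), not beyond the scatter, with an estimated value of 25 nM in the range 8 nM to 80 nM.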

Compound 4, inhibition constant: 8 nM
Compound 4: middle estimate off by 3.1-fold (0.49 log units), on the high side, and the stated range covers the measured number.
By their numbers in this assay, from the lowest: compound 4; then compound 2; then compound 1; then compound 3.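

In this assay the benzyl ring responds to substitution: chloro in place of hydrogen, on an aromatic carbon para to a large group, gives a 3.5-fold lower number from compound 2 to compound 4 (0.54 log units; beyond the scatter) and so provides the first read on this ring, which compounds 1 to 3 could not give. With the same shared core, 4-chlorophenyl in place of phenoxymethyl gives a 14-fold lower number from compound 1 to compound 4 (1.15 log units; beyond the scatter) as a large step, so the single chlorine extends the gain already seen on moving from the phenoxymethyl chain to the plain benzyl group. No supporting data are at hand to account for the direction or size of the chloro step.

Still open, on these data alone, is whether this gain is specific to chloro or would also appear with fluoro, methoxy or a carboxylic acid on the same carbon, and whether chloro on another carbon of the ring would behave alike. Also open, as far as these compounds go, is whether the 4-chlorobenzyl group would keep its gain on the core of compound 3, which carries (2-aminoethyl)amino in place of piperazin-1-yl.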